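Spiro core amides: a hydroxypiperidine swap on the side chain

The source may hold more compounds than are shown below. What is called first, only, known or untested is meant among the compounds shown, and "the series" means these compounds.

Of the compounds shown here, two with the shared core have been measured so far. Compound 1 `CC(C)(C)OC(=O)NCCCNC(=O)CN1CN(c2ccccc2)C2(CCN(C(=O)c3ccc(C4CCCCC4)cc3)CC2)C1=O` gives 6000 nM in an assay on HEK293 cells for displacement of a labelled ligand from NPC1-like intracellular cholesterol transporter 1 (Homo sapiens); a higher number here means a weaker inhibitor, a lower number a stronger inhibitor. Compound 2 `CC(C)(C)c1ccc(C(=O)N2CCC3(CC2)C(=O)N(CC(=O)N2CCCCC2CCO)CN3c2ccccc2)cc1` gives 6100 nM in this assay, and this sits within the scatter of the number for compound 1, so the two cannot be told apart on these data. For the measured compounds named here, no pair of measured compounds differs in a single place, so there is no measured step to lean on.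

Compound 3 `CC(C)(C)c1ccc(C(=O)N2CCC3(CC2)C(=O)N(CC(=O)N2CCC(O)CC2)CN3c2ccccc2)cc1` differs from compound 2 in one place: 4-hydroxypiperidin-1-yl in place of 2-(2-hydroxyethyl)piperidin-1-yl on a carbonyl carbon. Because compound 1 gives 6000 nM and compound 2 gives 6100 nM in this assay, two numbers within the scatter of each other despite their different amide substituents, the ring attached to the carbonyl carbon here appears not to move the number much, and the step is expected to stay within the scatter. The estimated step of a 1.0-fold lower number from compound 2 to compound 3 (0.01 log units; within the scatter) is therefore small, without a clear direction. Compound 3 is expected to give about 6000 nM in this assay, with a range from 2500 nM to 15000 nM.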

Compound 3, half-maximal inhibitory concentration: 4700 nM
Beside the measured number, compound 3's estimate is 1.3-fold (0.11 log units) above it, within the range that was stated.
By their numbers in this assay, from the lowest: compounds 3, 1 and 2 (each within the scatter of the next).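

In this assay, the swap on the carbonyl carbon gives a 1.3-fold lower number from compound 2 to compound 3 (0.11 log units; within the scatter), so compound 2 and compound 3 cannot be told apart. For the compounds shown here, this is the first single-place comparison, and it shows that, with the rest of the molecule held constant, 4-hydroxypiperidin-1-yl and 2-(2-hydroxyethyl)piperidin-1-yl are not distinguished at this position. The reading is narrow, since both groups are six-membered non-aromatic rings with a single hetero atom, carry the same counts of hydrogen-bond donors and acceptors and have no net charge, and no information is available to explain the result.

The compounds shown leave open whether the hydroxyl group matters at all, which a plain piperidin-1-yl or a morpholin-4-yl on the same carbonyl carbon would address. They also leave open whether a group of a different kind there, such as a piperidine bearing a carboxylic acid or a primary amine, or an open chain in place of the ring, would move the number beyond the scatter.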